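Nitro on the pendant phenyl of compound 1

A few compounds are considered here, and "the series" means these few. Any claim that something is new, unique, unknown or untested is made for them only; others in the source may bear on it.

Compound 1 `C=C(C)C(=O)c1ccc(OCc2nc(-c3ccccc3)cs2)cc1Cl` stands in an assay on HL-60 cells for inhibition of glutathione S-transferase P (Homo sapiens), read by spectrophotometry, tested at 5 uM (a higher number here means more inhibition at the concentration tested (going by the name of the read-out), a lower number less inhibition), at 100%, level with compound 2 `C=C(C)C(=O)c1ccc(OCc2nc(-c3ccccc3)cs2)cc1C`, which gives 100%; these two values are the highest of the three measured and lie within the scatter of each other. The step of no change at the digits printed from compound 1 to compound 2 (within the scatter) shows that a methyl in place of chloro on an aromatic carbon leaves the read-out where it was. Compound 3 `C=C(CC)C(=O)c1ccc(OCc2nc(-c3ccc([N+](=O)[O-])cc3)cs2)c(C)c1C` gives 4.4%, well below compound 1, but it differs from compound 1 in several places at once, so no single change can be read from that pair.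

Compound 4 `C=C(C)C(=O)c1ccc(OCc2nc(-c3ccc([N+](=O)[O-])cc3)cs2)cc1Cl` differs from compound 1 by nitro in place of hydrogen on an aromatic carbon. For the measured compounds named here, the only measured step, from compound 1 to compound 2, concerns another group at another position and does not bear on this change. Compound 3 carries the same 4-nitrophenyl and its value of 4.4% is the only hint available, yet its other differences from compound 1 make it an uncertain guide. The step of a number 25 percentage points lower from compound 1 to compound 4 (beyond the scatter) is therefore expected to be a loss of modest size at most, with wide uncertainty. Compound 4 is estimated at 75%, with a range from 30% to 100%.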

Compound 4, a percentage reported as inhibition, at one concentration (the size of the read-out at that concentration, not a potency): 86.7%
For compound 4 the middle estimate is 11.7 percentage points below the measured one; the measured number falls inside the stated range.
By their numbers in this assay, from the lowest: compound 3; then compound 4; then compounds 1 and 2 (each within the scatter of the next).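

In this assay, for the compounds shown here, the change from phenyl to 4-nitrophenyl on the core of compound 1 gives a number 13.3 percentage points lower from compound 1 to compound 4 (beyond the scatter) and is the first reading at this position, since the earlier step concerned only the replacement of chloro by methyl elsewhere on the core. The position para to a large group therefore accepts nitro with a modest loss, and compound 4 keeps 86.7% in this read-out, which is taken at one concentration and is not a potency. No measurement at hand bears on why the read-out falls with nitro in place of hydrogen.

On these data alone, whether the modest loss is particular to nitro remains open, as an amine, a carboxylic acid or a methoxy group at the same position on the pendant phenyl would be needed to show how far this position accepts other groups. The low number of compound 3 at 4.4% also remains unassigned, as this compound differs from compound 4 in more than one place and no single change can be read from that pair.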